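This account rests on a few compounds, and the source may have more. Where it says the series, first, only, none or still open, it means among the compounds named here.

The measured compounds, with their numbers in an assay for displacement of a labelled ligand from Adrenergic receptor alpha-1 (Homo sapiens); a higher number here means a weaker inhibitor, a lower number a stronger inhibitor:

compound 1, `CNc1ccccc1N1CCN(CCCCn2ncc(=O)n(C)c2=O)CC1`, gives 450 nM
compound 2, `CSc1ccccc1N1CCN(CCCCn2ncc(=O)n(C)c2=O)CC1`, gives 1.8 nM
compound 3, `Cn1c(=O)cnn(CCCCN2CCN(c3ccccc3C#N)CC2)c1=O`, gives 7.3 nM

Compound 3 stands second of the three in this assay: it sits nearest to compound 2, a step of a 4.1-fold higher number from compound 2 to compound 3 (0.61 log units; beyond the scatter), and furthest from compound 1, from which it differs by a 62-fold lower number from compound 1 to compound 3 (1.79 log units; beyond the scatter).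

Compound 4, `Cn1c(=O)cnn(CCCCN2CCN(c3cccc(O)c3)CC2)c1=O`, has not been measured. It differs from compound 3 in one place: 3-hydroxyphenyl in place of 2-cyanophenyl on an amine nitrogen in a ring. The three measured steps all swap the group on the aromatic carbon of the phenyl ring while the ring itself stays in place; they show that this group matters a great deal, since a 250-fold lower number from compound 1 to compound 2 (2.40 log units; beyond the scatter) and a 62-fold lower number from compound 1 to compound 3 (1.79 log units; beyond the scatter) are large, whereas a 4.1-fold higher number from compound 2 to compound 3 (0.61 log units; beyond the scatter) is modest. Among the compounds with values here, none of them replaces the whole 2-cyanophenyl by a 3-hydroxyphenyl, so no measured step bears directly on the change to compound 4. Given that every substitution seen so far shifted the number beyond the scatter, a step beyond the scatter is expected here too, and in the direction of a higher number, since compound 3 already lies near the strongest measured value. The estimated step is a 5.5-fold higher number from compound 3 to compound 4 (0.74 log units; beyond the scatter). Compound 4 is therefore expected at about 40 nM, with a range of 5 nM to 300 nM.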

Compound 4, inhibition constant: > 10000 nM
Compound 4: only a limit was reported; the forecaster's own chance of this, stated with the estimate: 3%; at least 250-fold (2.39 log units) between middle value and limit.
By their numbers in this assay, from the lowest: compound 2; then compound 3; then compound 1. At a limit, above all of these: compound 4.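

In this assay, the reading for compound 4 is a limit of the assay and not a number: the limit of > 10000 nM in this assay, at which 1 of the 4 values shown sits. The earlier steps shown here only exchanged one group within a series of 2-substituted phenyls, whereas replacing the whole aryl group on the amine nitrogen in the ring goes further, with an at least 1300-fold higher number from compound 3 to compound 4 (3.13 log units; beyond the scatter) and an at least 5500-fold higher number from compound 2 to compound 4 (3.74 log units; beyond the scatter), and even the weakest earlier compound gives an at least 22-fold higher number from compound 1 to compound 4 (1.34 log units; beyond the scatter). Thus 2-cyanophenyl, 2-(methylsulfanyl)phenyl and 2-(methylamino)phenyl all gave measurable values at this position, though these spanned a wide range, while 3-hydroxyphenyl is the only group here that reaches the limit.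

The change to compound 4 alters both the identity of the group on the phenyl ring and where it sits, so the compounds shown cannot separate these two changes; a 2-hydroxyphenyl or a 3-cyanophenyl on the same ring nitrogen would be needed to tell them apart. Going by these compounds, it also remains open how far compound 4 lies beyond the limit, and whether a 3-methoxyphenyl or an unsubstituted phenyl would stay at the limit or return to a measurable value.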